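The source may hold more compounds than are shown below. What is called first, only, known or untested is meant among the compounds shown, and "the series" means these compounds.

Measured compounds in a functional assay on LoVo cells (Homo sapiens) for cytotoxicity, read by MTT assay, with a stated time of 24 h; on this read-out lower numbers stand for stronger inhibition and higher numbers for weaker inhibition:
compound 1, `C=C1C(=O)[C@H]2C[C@]1(O)CC1=C2[C@]2(C)CCCC(C)(C)[C@H]2CC1`, 2300 nM
compound 2, `C=C1C(=O)[C@H]2C[C@@H]1CC1=C2[C@]2(C)CCC[C@](C)(CO)[C@H]2CC1`, 35200 nM
compound 3, `C[C@@H]1C(=O)[C@H]2C[C@]1(O)CC1=C2[C@]2(C)CCC[C@](C)(CO)[C@H]2CC1`, a limit only

Compound 1 gives 2300 nM and compound 2 gives 35200 nM in this assay. For compound 3 the assay reports only a limit, > 50000 nM, so compound 3 stands at the weak end of the numbers shown; (the limit of > 50000 nM in this assay, at which 1 of the 3 values shown sits). Compound 4, `C[C@@H]1C(=O)[C@H]2C[C@]1(O)CC1=C2[C@]2(C)CCCC(C)(C)[C@H]2CC1`, differs from compound 3 in one place: hydrogen in place of hydroxy on a saturated chain carbon bound to a saturated ring carbon. Among the measured compounds shown here, no measured pair shares exactly this change, so the size of the step is uncertain. The step from compound 3 to compound 4 is expected to be an at least 2.5-fold lower number from compound 3 to compound 4 (0.39 log units; beyond the scatter), toward stronger inhibition, since a limit leaves room only in that direction. Compound 4 is estimated at 20000 nM, within 5000 nM to 50000 nM.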

Compound 4, half-maximal inhibitory concentration: > 50000 nM
Compound 4 gave a limit, no number; the forecaster's own chance of this, stated with the estimate: 30%; at least 2.5-fold (0.39 log units) between middle value and limit.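

Compound 3 and compound 4 each give only a limit, not a number, so no step between them can be read: the limit of > 50000 nM in this assay, at which 2 of the 4 values shown sit.

As far as these compounds go, whether hydrogen in place of hydroxy changes the strength of inhibition at all stays open.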